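Swapping the Aryl Group on a Fatty Acid Receptor Agonist

The source may hold more compounds than are shown below. What is called first, only, known or untested is meant among the compounds shown, and "the series" means these compounds.

Compound 1 `CC#CC(CC(=O)O)c1ccc(OCc2ccn3cc(-c4cccc(C)c4)nc3c2)cc1`: 1510 nM
Compound 2 `CC#CC(CC(=O)O)c1ccc(OCc2ccc3nc(-c4cccc(C)c4)cn3c2)cc1`: 1050 nM
Compound 3 `CC#CC(CC(=O)O)c1ccc(OCc2ccc3nc(-c4ccccc4F)cn3c2)cc1`: 583 nM

Of the compounds shown here, three have so far been measured in an assay on isolated protein for agonist activity at Free fatty acid receptor 1 (Homo sapiens); a lower number here means that less compound is needed, a higher number that more compound is needed for the effect. Compound 1 gives the highest number of the three; compound 2 sits nearest, within the scatter, while compound 3 lies beyond it. Compound 4 `CC#CC(CC(=O)O)c1ccc(OCc2ccn3cc(-c4ccc(CC)cc4)nc3c2)cc1` differs from compound 1 in one place: 4-ethylphenyl in place of 3-methylphenyl on an aromatic carbon. Within the data shown here, the only measured single change, a 1.8-fold lower number from compound 2 to compound 3 (0.26 log units; within the scatter), exchanges 3-methylphenyl for 2-fluorophenyl on the core of compound 2 and stays within the scatter. Among the measured compounds shown here, it is the sole guide here, and it says nothing about an ethyl group, so the expectation is a step no larger than the scatter, a 1.2-fold lower number from compound 1 to compound 4 (0.07 log units; within the scatter). Compound 4 is therefore estimated at 1300 nM, with a range from 450 nM to 3800 nM.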

Compound 4, half-maximal effective concentration: 671 nM
The estimate for compound 4 lay 1.9-fold (0.29 log units) above the measured number; the measured number falls inside the stated range.
By their numbers in this assay, from the lowest: compounds 3, 4, 2 and 1 (each within the scatter of the next, the first and the last beyond it).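

In this assay, exchanging 3-methylphenyl for 4-ethylphenyl on the five-membered ring gives a 2.3-fold lower number from compound 1 to compound 4 (0.35 log units; beyond the scatter). Unlike the earlier aryl exchange on the other core, this step clears the scatter, showing that the number responds to the aryl group at this position. No available evidence accounts for the shift.

This step changes both the chain and its place on the phenyl ring, and the two effects cannot be separated here. Also open, on these data alone, is how a longer chain, such as 4-butylphenyl, or an amine on that ring would read in this assay.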